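Swapping Bromo for Methoxy on a Shared Anilinopyrimidine Core

The source may hold more compounds than are shown below. What is called first, only, known or untested is meant among the compounds shown, and "the series" means these compounds.

Compound 1 `COc1ccc(-c2ccnc(Nc3ccc([N+](=O)[O-])cc3)n2)cc1` gives 537 nM in an assay on isolated protein for inhibition of phosphatidylinositol 4,5-bisphosphate 3-kinase catalytic subunit beta isoform (Homo sapiens); on this read-out lower numbers stand for stronger inhibition and higher numbers for weaker inhibition.
Compound 2 `COc1ccc(-c2ccnc(Nc3ccc(Cl)cc3Cl)n2)cc1` gives 839 nM in this assay.
Compound 3 `Clc1ccc(Nc2nccc(-c3ccc(Br)cc3)n2)cc1` gives 946 nM in this assay.

Among these three measured compounds, compound 3 carries the highest number, yet the gaps to compound 2 and to compound 1 both fall within the usual scatter of repeated measurements, so the three cannot be told apart with confidence. Compound 4 `COc1ccc(-c2ccnc(Nc3ccc(Cl)cc3)n2)cc1` has not yet been measured. Its change from compound 3 is methoxy in place of bromo on an aromatic carbon, the position lying para to a large group. Among the measured compounds shown here, no pair of measured compounds differs by exactly this change, so no measured step can guide the expectation directly. The methoxy-bearing compounds 1 and 2 sit at numbers close to compound 3, which argues against a large shift in either direction. The step from compound 3 to compound 4 is therefore expected to be small, a 1.3-fold lower number from compound 3 to compound 4 (0.10 log units; within the scatter), not clearly beyond the scatter. Compound 4 is expected to give about 750 nM in this assay, with a plausible range from 350 nM to 1600 nM.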

Compound 4, half-maximal inhibitory concentration: 603 nM
Beside the measured number, compound 4's estimate is 1.2-fold (0.09 log units) above it; measured number inside the range.
By their numbers in this assay, from the lowest: compounds 1, 4, 2 and 3 (each within the scatter of the next).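

In this assay, methoxy in place of bromo on an aromatic carbon, para to a large group, can now be read directly as a single change: a 1.6-fold lower number from compound 3 to compound 4 (0.20 log units; within the scatter). The other two single changes also stay within the scatter: hydrogen in place of chloro gives a 1.4-fold lower number from compound 2 to compound 4 (0.14 log units; within the scatter), and chloro in place of nitro gives a 1.1-fold higher number from compound 1 to compound 4 (0.05 log units; within the scatter). Nothing available explains why these swaps leave the number within the scatter.

At the position para to a large group, the compounds shown carry only bromo and methoxy, so the range of groups tested there is narrow. As far as these compounds go, whether an amine, a carboxylic acid or a longer chain at that position would move the number beyond the scatter remains open.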